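Adding benzoyl to compound 2

The compounds below may be only part of what the source reports. "The series", "measured", "known", "first", "only" and "open" are said of these compounds alone.

Compound 2 (`OC[C@@H]1C[C@@H](O)[C@H](n2cnc3c(Cl)ncnc32)O1`) gives > 200000 nM in an ADME assay on Huh-7 cells (Homo sapiens) for cytotoxicity, read by XTT assay (a higher number here means that more compound is tolerated, a lower number that less compound is tolerated), and this is a limit of the assay, not a number. Compound 3 (`O=C(OC[C@@H]1C[C@@H](O)[C@H](n2cnc3c(Cl)ncnc32)O1)c1ccccc1`) differs from compound 2 by benzoyl in place of hydrogen on an oxygen on a saturated carbon with benzoyl in place of hydrogen on an oxygen on a saturated carbon. Among the compounds with values here, compound 1 (`O=C(OC[C@H]1O[C@@H](n2cnc3c(Cl)ncnc32)[C@H](O)[C@@H]1O)c1ccccc1`) also carries benzoyl and gives 97300 nM in this assay as the only numeric guide. With compound 1 at 97300 nM as that guide, a downward step beyond the scatter is expected, towards less compound tolerated. The estimated change is an at least 2.3-fold lower number from compound 2 to compound 3 (0.37 log units; beyond the scatter) in this read-out. Compound 3 is estimated at 85000 nM within a range from 35000 nM to 200000 nM for now.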

Compound 3, half-maximal cytotoxic concentration: 70500 nM
Beside the measured number, compound 3's estimate is 1.2-fold (0.08 log units) above it; the range from low to high includes it.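

In this assay, benzoyl in place of hydrogen on an oxygen on a saturated carbon gives an at least 2.8-fold lower number from compound 2 to compound 3 (0.45 log units; beyond the scatter) and so puts a first floor under this change, with less compound tolerated once benzoyl is present. On these data alone, the size of that step stays open-ended: the limit of > 200000 nM in this assay, at which 1 of the 3 values shown sits. With benzoyl present on both compounds, hydrogen in place of hydroxy on a saturated ring carbon gives a 1.4-fold lower number from compound 1 to compound 3 (0.14 log units; within the scatter) and so does not separate them.

As far as these compounds go, whether the step belongs to benzoyl itself remains open. Acetyl or a longer-chain acyl group on the same oxygen would address this.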